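From 4-nitrophenyl to 2-nitrophenyl in compound 4

The source may report more compounds than this note shows. Statements on the series, on what has been measured and on what is new or still open speak of the compounds shown alone.

Compound 1 `CC1(C)C=C(n2ccccc2=O)c2cc(C(=O)c3ccccc3)ccc2O1`, compound 2 `COc1ccc(C(=O)c2ccc3c(c2)C(n2ccccc2=O)=CC(C)(C)O3)cc1` and compound 3 `CC1(C)C=C(n2ccccc2=O)c2cc(C(=O)c3ccc([N+](=O)[O-])cc3)ccc2O1` share one core and differ only in a single group on an aromatic carbon. In a functional assay (trachea) with Rattus norvegicus as the target (a lower number here means a less potent compound, a higher number a more potent compound, by a factor of ten per unit of this negative logarithm), compound 1 gives 6.21. In this assay compound 2 gives 5.72, and in this assay compound 3 gives 6.09. The step of a number 0.49 log units lower from compound 1 to compound 2 (beyond the scatter) is modest, whereas a number 0.12 log units lower from compound 1 to compound 3 (within the scatter) stays within the scatter; in line with both, a number 0.37 log units higher from compound 2 to compound 3 (beyond the scatter). Compound 3 therefore holds the second highest of the three numbers, close to compound 1 and apart from compound 2.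

Compound 4 `CC1(C)C=C(n2ccccc2=O)c2cc(C(=O)c3ccccc3[N+](=O)[O-])ccc2O1` has the same atoms as compound 3, joined differently: 2-nitrophenyl in place of 4-nitrophenyl on a carbonyl carbon. Going by the values given here, no measured step moves a group from one aromatic carbon to another; the two steps that involve nitro, a number 0.12 log units lower from compound 1 to compound 3 (within the scatter) and a number 0.37 log units higher from compound 2 to compound 3 (beyond the scatter), show only that nitro at its present place sits about level with hydrogen. The expected step is accordingly small, a number 0.09 log units lower from compound 3 to compound 4 (within the scatter), and should not leave the scatter. Compound 4 is estimated at 6, with a range from 5.4 to 6.5.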

Compound 4, logarithm of the reciprocal of the active concentration, log(1/C): 5.64
Beside the measured number, compound 4's estimate is 0.36 log units above it; the measured number falls inside the stated range.
By their numbers in this assay, from the lowest: compounds 4 and 2 (each within the scatter of the next); then compounds 3 and 1 (each within the scatter of the next).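

In this assay, going by these compounds alone, the earlier compounds showed nitro only as 4-nitrophenyl, and the new result shows that where the nitro sits matters even with the same atoms: 2-nitrophenyl in place of 4-nitrophenyl gives a number 0.45 log units lower from compound 3 to compound 4 (beyond the scatter). The 2-nitrophenyl group also departs from the plain phenyl group, with a number 0.57 log units lower from compound 1 to compound 4 (beyond the scatter), so the closeness of nitro to hydrogen seen with 4-nitrophenyl does not carry over to 2-nitrophenyl. Set against 4-methoxyphenyl, it gives a number 0.08 log units lower from compound 2 to compound 4 (within the scatter), so these two substituted phenyl groups cannot be told apart here.

Nothing available accounts for the effect of moving the nitro. On these data alone, it remains open whether an amine or a carboxylic acid on this phenyl ring would follow the nitro group's pattern, or whether the pattern belongs to nitro alone.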